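A few compounds are considered here, and "the series" means these few. Any claim that something is new, unique, unknown or untested is made for them only; others in the source may bear on it.

Three compounds built on a shared pyridine-type core were tested in a functional assay on HCT-15 cells (Homo sapiens) for cytotoxicity, read by CCK-8 assay and cell counting, with a stated time of 2 days; on this read-out higher numbers stand for weaker inhibition and lower numbers for stronger inhibition. Compound 1 `Oc1ccc(-c2cc(-c3ccccc3)nc(-c3ccccc3Cl)c2)cc1` gives 4990 nM, compound 2 `Oc1ccc(-c2cc(-c3ccco3)nc(-c3ccccc3Cl)c2)cc1` gives 5460 nM, and compound 3 `Oc1cccc(-c2cc(-c3ccccc3)nc(-c3ccc(Cl)cc3)c2)c1` gives 8110 nM. The change from compound 1 to compound 2 is furan-2-yl in place of phenyl on an aromatic carbon, and it produced a 1.1-fold higher number from compound 1 to compound 2 (0.04 log units; within the scatter). Compound 3 and compound 1 are made of the same atoms joined differently; the difference between the two cores is not broken down here, and their two values lie within the usual scatter of each other.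

Compound 4 `Oc1cccc(-c2cc(-c3ccc(Cl)cc3)nc(-c3ccco3)c2)c1` has not yet been measured. Its difference from compound 3 is furan-2-yl in place of phenyl on an aromatic carbon. This is the same kind of change as that from compound 1 to compound 2, though the surroundings differ: in compound 3 the place is meta to a 3-hydroxyphenyl group and meta to a 4-chlorophenyl group, whereas in compound 1 it is meta to a 2-chlorophenyl group and meta to a 4-hydroxyphenyl group.

Because the earlier exchange gave a 1.1-fold higher number from compound 1 to compound 2 (0.04 log units; within the scatter), the step of a 1.1-fold higher number from compound 3 to compound 4 (0.04 log units; within the scatter) is expected to stay within the scatter. Compound 4 is therefore estimated at 8800 nM, with a range of 4000 nM to 20000 nM.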

Compound 4, half-maximal inhibitory concentration: 10200 nM
The estimate for compound 4 lay 1.2-fold (0.06 log units) below the measured number; the range from low to high includes it.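

In this assay, furan-2-yl in place of phenyl, next to the ring nitrogen, gave a 1.3-fold higher number from compound 3 to compound 4 (0.10 log units; within the scatter). Set beside the earlier exchange, the two steps show no difference between the cores: the same change on two cores in this assay, a 1.1-fold higher number (0.04 log units; within the scatter) from compound 1 to compound 2 and a 1.3-fold higher number (0.10 log units; within the scatter) from compound 3 to compound 4, 1.1-fold (0.06 log units) apart, within the scatter of two such steps In this series, then, the exchange stayed within the scatter on both the core of compound 1 and the core of compound 3, but this rests on only two pairs, and it does not show that the exchange would be equally silent on any other core or in any other assay.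

The compounds shown carry only the aromatic rings phenyl and furan-2-yl at this place, which leaves open how an amine, a carboxylic acid or a longer chain would read there. They also leave open what a methoxy group in place of the hydroxyl of the 3-hydroxyphenyl group would do to the same exchange.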